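Replacing the Piperidinyl Ether Tail: Expected Exposure of Compound 4

This account rests on a few compounds, and the source may have more. Where it says the series, first, only, none or still open, it means among the compounds named here.

Three compounds have so far been measured in an ADME assay on the whole organism (strain FVB) for pharmacokinetics, with Mus musculus as the target, read by LC-MS, at a dose of 30 mg/kg by the oral route; a higher number here means more compound in the circulation at the dose given, a lower number less compound in the circulation:

Compound 1 `c1cc([C@H]2CC[C@]3(CC2)OOC2(O3)C3CC4CC(C3)CC2C4)ccc1OCCOC1CCNCC1` gives 9180 ng.h/mL.
Compound 2 `CC(C)(N)CCOc1ccc([C@H]2CC[C@]3(CC2)OOC2(O3)C3CC4CC(C3)CC2C4)cc1` gives 12300 ng.h/mL.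
Compound 3 `CC(C)(CN)Oc1ccc([C@H]2CC[C@]3(CC2)OOC2(O3)C3CC4CC(C3)CC2C4)cc1` gives 4840 ng.h/mL.

Compound 1 stands second highest of the three numbers. Its nearest neighbour is compound 2, with a 1.3-fold higher number from compound 1 to compound 2 (0.13 log units; within the scatter), and its furthest is compound 3, with a 1.9-fold lower number from compound 1 to compound 3 (0.28 log units; within the scatter). For the measured compounds named here, the only step that clears the scatter is between the other two, a 2.5-fold lower number from compound 2 to compound 3 (0.41 log units; beyond the scatter), a modest one.

Compound 4 `O[C@H]1CC[C@H](NCCCOc2ccc([C@H]3CC[C@]4(CC3)OOC3(O4)C4CC5CC(C4)CC3C5)cc2)CC1` has not yet been measured. It differs from compound 1 in a single place: ((4-hydroxycyclohexyl)amino)methyl in place of (piperidin-4-yl)oxy on a saturated chain carbon, two bonds along the chain from an oxygen on an aromatic ring. Going by the values given here, the change sits at the same position as the one from compound 1 to compound 2, which also replaced the (piperidin-4-yl)oxy group by an amine-bearing group and gave a number within the scatter. The step from compound 1 to compound 3, which reworked the whole tail on the aromatic oxygen, also stayed within the scatter. On this basis no step beyond the scatter is expected in this assay for compound 4, in either direction.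

Compound 4 is therefore estimated at 8000 ng.h/mL, with a likely range from 3500 ng.h/mL to 18000 ng.h/mL. This estimate means an expected step of a 1.1-fold lower number from compound 1 to compound 4 (0.06 log units; within the scatter).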

Compound 4, area under the concentration-time curve: 6570 ng.h/mL
Estimate against measurement, compound 4: 1.2-fold (0.09 log units) above; low and high end bracket the measured number.
By their numbers in this assay, from the lowest: compounds 3, 4, 1 and 2 (each within the scatter of the next, the first and the last beyond it).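

In this assay, the position on a saturated chain carbon, two bonds along the chain from an oxygen on an aromatic ring, takes ((4-hydroxycyclohexyl)amino)methyl in place of (piperidin-4-yl)oxy with no change beyond the scatter (a 1.4-fold lower number from compound 1 to compound 4 (0.15 log units; within the scatter)). The earlier step at this position, to the 1-amino-1-methylethyl of compound 2, involved an open-chain group, whereas this one shows that a larger group with a six-membered ring of carbon only and a hydroxyl on that ring also keeps the number within the scatter. Compound 4 also lies within the scatter of the two compounds that stand beyond the scatter of each other (a 1.4-fold higher number from compound 3 to compound 4 (0.13 log units; within the scatter) and a 1.9-fold lower number from compound 2 to compound 4 (0.27 log units; within the scatter)), so it does not separate from either of them.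

No measurement at hand gives a reason for these numbers. As far as these compounds go, all four tails carry an amine nitrogen, so it remains open how the number responds to a tail ending in a carboxylic acid, and whether a plain cyclohexylamino group without the hydroxyl, or a longer chain before the amine, would behave as compound 4 does.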